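Series notes: methoxy added to the carbamoylpyrrolidine of compound 2

A few compounds are considered here, and "the series" means these few. Any claim that something is new, unique, unknown or untested is made for them only; others in the source may bear on it.

Measured so far:
compound 1, `Cc1cc(C(=O)N2CCCCc3ccccc32)ccc1CNC(=O)N1CCC[C@H]1C(=O)OC(C)C`, gives 950 nM
compound 2, `Cc1cc(C(=O)N2CCCCc3ccccc32)ccc1CNC(=O)N1CCC[C@@H]1C(=O)N(C)C`, gives 380 nM

Among the measured compounds shown here, in a functional assay on HEK293 cells for agonist activity at Vasopressin V2 receptor (Homo sapiens), read by a luciferase reporter and cAMP accumulation (a higher number here means that more compound is needed for the effect, a lower number that less compound is needed), compound 2 stands at the lower of the two numbers; the single measured step is a 2.5-fold lower number from compound 1 to compound 2 (0.40 log units; beyond the scatter), and it concerns the exchange of the isopropyl ester for the dimethylamide on the pyrrolidine.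

Compound 3, `CO[C@@H]1C[C@@H](C(=O)N(C)C)N(C(=O)NCc2ccc(C(=O)N3CCCCc4ccccc43)cc2C)C1`, keeps the dimethylamide of compound 2 and differs only by 2-(dimethylcarbamoyl)-4-methoxypyrrolidin-1-yl in place of 2-(dimethylcarbamoyl)pyrrolidin-1-yl on a carbonyl carbon. For the measured compounds named here, no measured step bears on this change: the one step from compound 1 to compound 2 touches the group on the pyrrolidine carbon next to the ring nitrogen, whereas the methoxy of compound 3 enters on a different ring carbon, and nothing in the two measured compounds tests a substituent there. On these data the change is therefore expected to leave the number roughly where compound 2 stands, with no step beyond the scatter in either direction.

Compound 3 is estimated at 380 nM, within 120 nM to 1200 nM, which means an expected step of no change at the digits printed from compound 2 to compound 3 (within the scatter).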

Compound 3, half-maximal effective concentration: 4.7 nM
Compound 3: middle estimate off by 81-fold (1.91 log units), on the high side; the whole stated range lies above it.
By their numbers in this assay, from the lowest: compound 3; then compound 2; then compound 1.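

In this assay, among the compounds shown here, the pyrrolidine on the carbonyl carbon proves far more responsive than the earlier compounds could show: the added methoxy of 2-(dimethylcarbamoyl)-4-methoxypyrrolidin-1-yl gives an 81-fold lower number from compound 2 to compound 3 (1.91 log units; beyond the scatter) and so outweighs a 2.5-fold lower number from compound 1 to compound 2 (0.40 log units; beyond the scatter) by a wide margin. Replacing 2-(isopropoxycarbonyl)pyrrolidin-1-yl with the methoxy-bearing group gives a 200-fold lower number from compound 1 to compound 3 (2.31 log units; beyond the scatter) in all, and most of that drop comes with the methoxy and not with the exchange of ester for dimethylamide, so the ring substituent, not only the group that was varied first, now stands out as a main handle on this number in the series. Nothing at hand gives a measured reason for a step of this size.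

On these data alone, whether the gain belongs to the methoxy itself remains open, as a hydroxyl, a fluorine or a longer ethoxy chain in the same place could give a similar or a very different number. Also open is how much depends on the arrangement at the 2 defined stereocentres of the entering group, as the compounds shown hold only one such arrangement.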